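This account rests on a few compounds, and the source may have more. Where it says the series, first, only, none or still open, it means among the compounds named here.

Measured in a functional assay on HCC827 cells (Homo sapiens) for antiproliferative activity, read by MTT assay, with a stated time of 72 h; a lower number here means a stronger inhibitor, a higher number a weaker inhibitor:
compound 1 `CN1CCN(c2ccc(Nc3ncc4nc(Nc5ccc(F)cc5)n([C@H]5CCCC(NC(=O)OC(C)(C)C)C5)c4n3)cc2)CC1` gives 120 nM
compound 2 `CN1CCN(c2ccc(Nc3ncc4nc(Nc5ccc(F)cc5)n(-c5cccc(NC(=O)CO)c5)c4n3)cc2)CC1` gives 7.5 nM
compound 3 `CN1CCN(c2ccc(Nc3ncc4nc(Nc5ccccc5)n([C@@H]5CCN(S(=O)(=O)C6CC6)C5)c4n3)cc2)CC1` gives 0.88 nM

Compound 2 holds the middle place among these three, with 7.5 nM. Its number lies above that of compound 3 and below that of compound 1, and both gaps are beyond the scatter.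

The next compound is compound 4 `CN1CCN(c2ccc(Nc3ncc4nc(Nc5ccc(F)cc5)n(CCNS(=O)(=O)C5CC5)c4n3)cc2)CC1`, which has 2-((cyclopropylsulfonyl)amino)ethyl in place of 3-(((hydroxymethyl)carbonyl)amino)phenyl on an aromatic nitrogen. Among the compounds with values here, no two measured compounds differ in only one place, so no measured step shows what this swap does. One clue is that compound 3 also carries a cyclopropylsulfonyl group and gives 0.88 nM. Its group is otherwise different, however, so the clue is weak. In this assay the expected outcome is therefore no change beyond the scatter, with an estimated 1.3-fold higher number from compound 2 to compound 4 (0.12 log units; within the scatter). For compound 4 the estimated value is 10 nM, with an expected range of 1.5 nM to 70 nM.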

Compound 4, half-maximal inhibitory concentration: 50 nM
For compound 4 the middle estimate is 5.0-fold (0.70 log units) below the measured one; measured number inside the range.
By their numbers in this assay, from the lowest: compound 3; then compound 2; then compound 4; then compound 1.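

In this assay, this is the first step among the compounds shown that changes only one place, and it reveals that the group on this aromatic nitrogen matters: 2-((cyclopropylsulfonyl)amino)ethyl in place of 3-(((hydroxymethyl)carbonyl)amino)phenyl gives a 6.7-fold higher number from compound 2 to compound 4 (0.82 log units; beyond the scatter). The swap changes several things at once, removing the six-membered aromatic ring and replacing the hydroxymethyl carbonyl with cyclopropylsulfonyl, so the step cannot be assigned to any one of them. Nothing available explains why the number rises.

The compounds shown leave open whether the loss of the aromatic ring or the arrival of the cyclopropylsulfonyl group drives this step. A 3-((cyclopropylsulfonyl)amino)phenyl group would keep the ring while carrying the new sulfonyl group, and a 3-((cyclopropylsulfonyl)amino)propyl group would test a longer chain.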